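Selenium-to-sulfur exchange on a bis-acylated isothiourea-type core

The source may hold more compounds than are shown below. What is called first, only, known or untested is meant among the compounds shown, and "the series" means these compounds.

Measured so far
compound 1 `C[Se]/C(=N\C(=O)c1cccs1)NC(=O)c1cccs1`: 630 nM
compound 2 `C[Se]/C(=N\C(=O)c1sccc1Cl)NC(=O)c1sccc1Cl`: 690 nM

Notes on the series. In a functional assay on HepG2 cells (Homo sapiens) for cytotoxicity, read by MTT assay, with a stated time of 72 h (on this read-out higher numbers stand for weaker inhibition of growth and lower numbers for stronger inhibition of growth), compound 1 gives 630 nM and compound 2 gives 690 nM. The two numbers lie within the scatter of each other, so neither compound stands apart from the other on the read-out in hand; compound 2 simply carries the larger of two numbers that cannot be told apart.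

Compound 3 `CS/C(=N\C(=O)c1sccc1Cl)NC(=O)c1sccc1Cl` has not been measured in this assay. It differs from compound 2 as follows: a group of 2 heavy atoms (1 carbon, 1 sulfur; no ring) in place of a group of 2 heavy atoms (1 carbon, 1 selenium; no ring), on a carbon with a double bond to nitrogen. Among the measured compounds shown here, no step between two measured compounds with a change of this kind exists, so the expected size must rest on the two values alone. The expectation is a step of about a 1.3-fold higher number from compound 2 to compound 3 (0.12 log units; within the scatter), small and within the scatter, with no clear direction beyond it. On that basis compound 3 is estimated at 900 nM, within a range from 400 nM to 2500 nM.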

Compound 3, concentration for 50% growth inhibition: 65300 nM
For compound 3 the middle estimate is 73-fold (1.86 log units) below the measured one; measured number above the stated range.
By their numbers in this assay, from the lowest: compounds 1 and 2 (each within the scatter of the next); then compound 3.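

In this assay the position on the carbon with a double bond to nitrogen proves decisive: replacing the selenium-bearing group with methylsulfanyl gives a 95-fold higher number from compound 2 to compound 3 (1.98 log units; beyond the scatter). Both earlier compounds carry the selenium-bearing group, so they could not show this dependence. The two groups have the same heavy-atom count, yet in this pair growth inhibition is largely lost with the exchange of selenium for sulfur, and no measurement at hand accounts for the loss.

As far as these compounds go, it remains open whether the sulfur counterpart of compound 1 would show a step of similar size, which would indicate whether the effect carries over to a core without the chlorine atoms. Also open, from the compounds shown here alone, is whether a longer chain on selenium, such as ethyl or benzyl, or an amine at this carbon would retain growth inhibition.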